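Dropping a Methyl Group from an Aryl Urea: Expected Cytotoxicity

This account rests on a few compounds, and the source may have more. Where it says the series, first, only, none or still open, it means among the compounds named here.

Compound 1 `Cc1cc(NC(=O)Nc2ccc(C)c(Cl)c2)c2ccccc2n1` is a urea that carries a chloro group and a methyl group. In an ADME assay on BJ cells (Homo sapiens) for cytotoxicity, with a stated time of 72 h (on this read-out lower numbers stand for an effect already at smaller amounts and higher numbers for an effect only at larger amounts of compound), compound 1 gives > 25000 nM, which is a limit of the assay rather than a measured number. Compound 2 `Cc1cc(NC(=O)Nc2ccc(C(F)(F)F)cc2)c2ccccc2n1` carries a trifluoromethyl group. In this assay compound 2 gives > 25000 nM, again a limit and not a number. Compound 1 therefore sits at the limit of > 25000 nM in this assay, at which 2 of the 2 values shown sit, so no ordering among the measured compounds can be drawn from these values. Compound 3 `Cc1cc(NC(=O)Nc2cccc(Cl)c2)c2ccccc2n1` differs from compound 1 in one place: hydrogen in place of methyl on an aromatic carbon. Within the data shown here, no step between two measured compounds is available, so the effect of this change rests on expectation alone. Because (the limit of > 25000 nM in this assay, at which 2 of the 2 values shown sit), the step from compound 1 to compound 3 in this assay is expected to be none beyond the scatter, most likely leaving compound 3 at the same limit. This expectation is written as a step that the limit leaves unreadable from compound 1 to compound 3. For compound 3 the estimated value in this assay is 30000 nM, with a range from 10000 nM to 100000 nM.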

Compound 3, half-maximal effective concentration: > 25000 nM
Compound 3: no number, only a limit; the forecaster's own chance of this, stated with the estimate: 85%; the middle value is on the limit's open side.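

In this assay compound 3 gives > 25000 nM, which is a limit and not a number. No size can be read for the change from compound 1 to compound 3, because neither gives a number: the limit of > 25000 nM in this assay, at which 3 of the 3 values shown sit.

The compounds shown leave open whether hydrogen in place of methyl changes this read-out at all, and at what amount any of them would show an effect.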